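The compounds below may be only part of what the source reports. "The series", "measured", "known", "first", "only" and "open" are said of these compounds alone.

Compound 1 `CC(C)COc1ncc(-c2cn(C)c3cc(C(=O)NS(C)(=O)=O)ccc23)cc1Cl`: 443 nm/s
Compound 2 `CC(C)Cc1ccc(-c2cn(C)c3cc(C(=O)NS(C)(=O)=O)ccc23)cc1`: "not determined" (no result reported)

In an ADME assay for permeability, using PAMPA, at pH 5.5 (on this read-out lower numbers stand for lower permeability and higher numbers for higher permeability), compound 1 gives 443 nm/s. Going by the values given here, it is the only number available, as compound 2 has no reported result, so compound 1 cannot yet be ranked against anything. Compound 3 `CC(C)COc1ncc(-c2cn(C)c3cc(C(=O)NS(C)(=O)=O)c(F)cc23)cc1Cl` keeps the structure of compound 1 with one change: fluoro in place of hydrogen on an aromatic carbon. This places fluoro in place of hydrogen on an aromatic carbon, ortho to a (methylsulfonyl)carbamoyl group. Among the compounds with values here, no measured pair shows the effect of such a swap, so the expected change, a 1.0-fold lower number from compound 1 to compound 3 (0.00 log units; within the scatter), is none beyond the usual scatter, with no direction favoured. For compound 3 the estimated value is 440 nm/s, with an expected range of 200 nm/s to 900 nm/s.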

Compound 3, apparent permeability: 495 nm/s
Compound 3: the middle estimate sits 1.1-fold (0.05 log units) below what was measured; low and high end bracket the measured number.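

In this assay, going by these compounds alone, putting fluoro in place of hydrogen on an aromatic carbon, ortho to a (methylsulfonyl)carbamoyl group, gives a 1.1-fold higher number from compound 1 to compound 3 (0.05 log units; within the scatter), the first measured step at this position. This read-out therefore shows no change beyond the usual scatter when this hydrogen becomes fluoro. No measured information available here offers a reason for this result. Still open is how a methoxy group or an amine at the same position would read in this assay, since fluoro is the only replacement for hydrogen shown there.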